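Replacing the hydrazone aryl group on a triazine sulfonamide

The source may report more compounds than this note shows. Statements on the series, on what has been measured and on what is new or still open speak of the compounds shown alone.

Two triazine sulfonamides have been measured in a functional assay on UACC-62 cells (Homo sapiens) for inhibition, read by sulforhodamine B assay, with a stated time of 48 h (on this read-out higher numbers stand for weaker inhibition of growth and lower numbers for stronger inhibition of growth), so far. Compound 1 `NS(=O)(=O)c1ccc(Nc2nc(N/N=C/c3ccc(C(F)(F)F)cc3)nc(Nc3ccccc3)n2)cc1` gives 2350 nM in this assay. Compound 2 `Cc1nn(-c2ccccc2)cc1/C=N/Nc1nc(Nc2ccccc2)nc(Nc2ccc(S(N)(=O)=O)cc2)n1` gives 1780 nM in this assay, and the step of a 1.3-fold lower number from compound 1 to compound 2 (0.12 log units; within the scatter) shows that the two numbers sit within the usual scatter of each other, so compound 2 stands alongside compound 1 rather than apart from it.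

Compound 3 `NS(=O)(=O)c1ccc(Nc2nc(N/N=C/c3ccccn3)nc(Nc3ccccc3)n2)cc1` has not yet been measured. It differs from compound 2 in one place: pyridin-2-yl in place of 3-methyl-1-phenyl-1H-pyrazol-4-yl on a carbon with a double bond to nitrogen. Within the data shown here, the only measured step that bears on this position is the one from compound 1 to compound 2, which swapped one aryl group for another on the same carbon and stayed within the scatter. On that basis the exchange for a smaller aromatic ring in compound 3 is expected to leave the number close to where compound 2 stands, with no step beyond the scatter anticipated in either direction, which is the expectation behind a 1.4-fold higher number from compound 2 to compound 3 (0.15 log units; within the scatter). Compound 3 is therefore estimated at 2500 nM in this assay, within a range from 1000 nM to 6500 nM.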

Compound 3, concentration for 50% growth inhibition: 570 nM
Compound 3: the middle estimate sits 4.4-fold (0.64 log units) above what was measured; the whole stated range lies above it.
By their numbers in this assay, from the lowest: compound 3; then compounds 2 and 1 (each within the scatter of the next).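

This position turns out to be able to move the number after all: in this assay, pyridin-2-yl gives a 3.1-fold lower number from compound 2 to compound 3 (0.49 log units; beyond the scatter) and a 4.1-fold lower number from compound 1 to compound 3 (0.62 log units; beyond the scatter), both beyond the scatter, whereas the earlier exchange between 4-(trifluoromethyl)phenyl and 3-methyl-1-phenyl-1H-pyrazol-4-yl had not separated the two compounds. So the aromatic group on the carbon with a double bond to nitrogen is not interchangeable, and among these three compounds the stronger inhibition of growth belongs to compound 3 alone, while compounds 1 and 2 remain level with each other. No measurement is available that would explain this difference, so the step stands as an observation only.

The compounds shown leave open whether the lower number goes with the ring nitrogen of pyridin-2-yl or with the smaller group, since the two change together here, and a plain phenyl ring in the same place would help to separate them. From the compounds shown here alone, it also remains open how far this place tolerates something other than a single aromatic ring, such as a short alkyl chain, or whether the step would persist with a different group on the rest of the shared core.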